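A few compounds are considered here, and "the series" means these few. Any claim that something is new, unique, unknown or untested is made for them only; others in the source may bear on it.

Measured compounds in a functional assay on isolated protein for inhibition of Glucose-dependent insulinotropic receptor (Rattus norvegicus), read by HTRF and cAMP accumulation; a lower number here means that less compound is needed, a higher number that more compound is needed for the effect:
- compound 1, `Cc1nc(S(C)(=O)=O)ccc1Oc1ncnc(OC2CCN(C(=O)OC(C)(C)CF)CC2)c1F`, gives 138 nM
- compound 2, `Cc1nc(S(C)(=O)=O)ccc1Oc1ncnc(OC2CCN(C(=O)O[C@@H](C)CF)CC2)c1F`, gives 1680 nM
- compound 3, `Cc1nc(S(C)(=O)=O)ccc1Oc1ncnc(OC2CCN(C(=O)OC3COC3)CC2)c1F`, gives 2500 nM

Compound 3 carries the highest number of the three in this assay. Its nearest neighbour is compound 2, and the step of a 1.5-fold higher number from compound 2 to compound 3 (0.17 log units; within the scatter) stays within the scatter; the step of an 18-fold higher number from compound 1 to compound 3 (1.26 log units; beyond the scatter) is large and beyond it. Compound 4, `Cc1nc(S(C)(=O)=O)ccc1Oc1ncnc(OC2CCN(C(=O)OC3(C(F)(F)F)CCC3)CC2)c1F`, has not yet been measured. It differs from compound 3 in one place: 1-(trifluoromethyl)cyclobutyl in place of oxetan-3-yl on an oxygen next to a carbonyl group. The measured steps that bear on this change are the two that replace the group on the oxygen next to the carbonyl: a 12-fold higher number from compound 1 to compound 2 (1.09 log units; beyond the scatter) and an 18-fold higher number from compound 1 to compound 3 (1.26 log units; beyond the scatter), both large. Both show that the group of compound 1, which like the entering group of compound 4 carries fluorine and no hydrogen-bond acceptor, goes with a far lower number than the oxetan-3-yl or 1-(fluoromethyl)ethyl groups. A large step downward in this assay is therefore expected, an 11-fold lower number from compound 3 to compound 4 (1.06 log units; beyond the scatter). For compound 4 the estimate is 220 nM, with a range from 60 nM to 800 nM.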

Compound 4, half-maximal effective concentration: 63.3 nM
The estimate for compound 4 lay 3.5-fold (0.54 log units) above the measured number; measured number inside the range.
By their numbers in this assay, from the lowest: compound 4; then compound 1; then compounds 2 and 3 (each within the scatter of the next).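

In this assay, 1-(trifluoromethyl)cyclobutyl on an oxygen next to a carbonyl group gives a 39-fold lower number from compound 3 to compound 4 (1.60 log units; beyond the scatter) and also a 27-fold lower number from compound 2 to compound 4 (1.42 log units; beyond the scatter) in the comparison with the two groups at the high end of the series. Against the best earlier group the result is a 2.2-fold lower number from compound 1 to compound 4 (0.34 log units; beyond the scatter) and this modest step shows that the low number is not tied to 1-(fluoromethyl)-1-methylethyl and that this place accepts a group of 8 heavy atoms with a four-membered ring of carbon only. Among the four compounds, fluorine alone does not bring the low number, since compound 2 carries fluorine yet stays within the scatter of compound 3, which has none.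

From the compounds shown here alone, whether a plain cyclobutyl group without the trifluoromethyl, a tert-butyl group or a 1-(trifluoromethyl)cyclopropyl group would hold the number this low remains open. Nothing shown here gives a reason for these differences.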